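Para substituent swap on the cyclopentyl aryl ring

The source may report more compounds than this note shows. Statements on the series, on what has been measured and on what is new or still open speak of the compounds shown alone.

Three ureas sharing one core have been measured in an assay on microsomes for inhibition of acyl-CoA:cholesterol acyltransferase (Oryctolagus cuniculus); a lower number here means a stronger inhibitor, a higher number a weaker inhibitor. Compound 1 `Cc1ccccc1C1(CNC(=O)Nc2c(C(C)C)cccc2C(C)C)CCCC1` gives 17 nM. Compound 2 `CC(C)c1cccc(C(C)C)c1NC(=O)NCC1(c2ccc(F)cc2)CCCC1`, carrying a 4-fluorophenyl group, gives 23 nM. Compound 3 `CC(C)c1cccc(C(C)C)c1NC(=O)NCC1(c2ccc(Cl)cc2)CCCC1`, carrying a 4-chlorophenyl group, gives 32 nM. All three sit close together: a 1.4-fold higher number from compound 1 to compound 2 (0.13 log units; within the scatter), a 1.9-fold higher number from compound 1 to compound 3 (0.27 log units; within the scatter) and a 1.4-fold higher number from compound 2 to compound 3 (0.14 log units; within the scatter). Compound 3 therefore carries the largest of the three numbers, but its gaps to compound 2 and to compound 1 are both within the scatter, so the three cannot be told apart on this evidence.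

Compound 4 `COc1ccc(C2(CNC(=O)Nc3c(C(C)C)cccc3C(C)C)CCCC2)cc1` has not yet been measured. It differs from compound 3 in one place: methoxy in place of chloro on an aromatic carbon. The measured steps that bear on this change are the three swaps of the group on the phenyl ring, which all stayed within the scatter. On that basis no step beyond the scatter is expected in this assay for compound 4, and the expected step is a 1.1-fold lower number from compound 3 to compound 4 (0.03 log units; within the scatter). Compound 4 is therefore estimated at 30 nM, with a range from 12 nM to 80 nM.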

Compound 4, half-maximal inhibitory concentration: 31 nM
For compound 4 the middle estimate is 1.0-fold (0.01 log units) below the measured one; low and high end bracket the measured number.
By their numbers in this assay, from the lowest: compounds 1, 2, 4 and 3 (each within the scatter of the next).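

In this assay, methoxy on the aromatic carbon para to a large group cannot be told apart from chloro, a 1.0-fold lower number from compound 3 to compound 4 (0.01 log units; within the scatter), or from fluoro, a 1.3-fold higher number from compound 2 to compound 4 (0.13 log units; within the scatter). This extends the earlier picture in a concrete way: the entering methoxy has 2 heavy atoms where chloro has 1, and it brings 1 hydrogen-bond acceptor where chloro and fluoro bring none, yet neither step leaves the scatter. The 4-methoxyphenyl group also stays close to the 2-methylphenyl group, a 1.8-fold higher number from compound 1 to compound 4 (0.26 log units; within the scatter), so all four compounds remain a single group in this assay, with no substituent at this position yet separating from the others.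

No supporting measurement is available to explain why these swaps leave the number within the scatter. Still open, as far as these compounds go, is whether an amine, a carboxylic acid or a longer chain such as butoxy on the same aromatic carbon would also stay within the scatter, or would finally produce a step large enough to read.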